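From 1-methoxy-1-methylethyl to cyclohexyl

The source may report more compounds than this note shows. Statements on the series, on what has been measured and on what is new or still open speak of the compounds shown alone.

In a functional assay on a cell-free system (plasma, Homo sapiens), with a stated time of 3 min (a higher number here means a weaker inhibitor, a lower number a stronger inhibitor), compound 1 `CC1(C[C@@H](O)C(=O)N2N=CC[C@H]2C(=O)NCc2cc(Cl)ccc2-n2cnnn2)CC1` gives 730 nM, while compound 2 `COC(C)(C)[C@@H](O)C(=O)N1N=CC[C@H]1C(=O)NCc1cc(Cl)ccc1-n1cnnn1` gives 3700 nM, the higher of the two numbers. Compound 3 `O=C(NCc1cc(Cl)ccc1-n1cnnn1)[C@@H]1CC=NN1C(=O)[C@H](O)C1CCCCC1` has not yet been measured. It carries cyclohexyl in place of the 1-methoxy-1-methylethyl of compound 2, on the same saturated chain carbon: cyclohexyl in place of 1-methoxy-1-methylethyl on a saturated chain carbon bound to a carbonyl carbon and an oxygen on a saturated carbon. Going by the values given here, only one measured step bears on this change. That step, a 5.1-fold higher number from compound 1 to compound 2 (0.70 log units; beyond the scatter), brought in 1-methoxy-1-methylethyl in place of (1-methylcyclopropyl)methyl at the same place. Cyclohexyl, like the group it resembles in compound 1, is made of carbon only, so a move back towards a lower number is expected, although no cyclohexyl compound has been measured yet. The expected change is a 4.1-fold lower number from compound 2 to compound 3 (0.61 log units; beyond the scatter), of modest size. For compound 3 the estimate is 900 nM, with an expected range of 250 nM to 3000 nM.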

Compound 3, half-maximal inhibitory concentration: 970 nM
Compound 3: the middle estimate sits 1.1-fold (0.03 log units) below what was measured; measured number inside the range.
By their numbers in this assay, from the lowest: compounds 1 and 3 (each within the scatter of the next); then compound 2.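

In this assay the move to cyclohexyl gives a 3.8-fold lower number from compound 2 to compound 3 (0.58 log units; beyond the scatter) and so recovers what was lost with 1-methoxy-1-methylethyl, while a 1.3-fold higher number from compound 1 to compound 3 (0.12 log units; within the scatter) shows that cyclohexyl and (1-methylcyclopropyl)methyl cannot be told apart at this place. Two different groups made of carbon only, one with a six-membered ring and one with a methylcyclopropyl end, therefore read alike on this saturated chain carbon, and among these three compounds only compound 2, the one whose group carries oxygen, stands apart. No measurement at hand explains this difference.

Going by these compounds, neither step changes the oxygen alone, so it remains open whether the oxygen or the rest of 1-methoxy-1-methylethyl sets compound 2 apart, a question that a tert-butyl group at the same place would address. On these data alone, how a phenyl ring or an amine would read on this carbon also remains open.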